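The source may report more compounds than this note shows. Statements on the series, on what has been measured and on what is new or still open speak of the compounds shown alone.

Measured compounds in the series:
- compound 1, `Cc1c(OCCCCOc2ccc(C(=O)O)cc2F)ccc(C(=O)CC2CCCC2)c1O`: > 10000 nM
- compound 2, `Cc1c(OCCCCOc2ccc(F)c(C(=O)O)c2)ccc(C(=O)C(C)C)c1O`: > 10000 nM

Both values in an assay on HEK293 cells for positive allosteric modulation of metabotropic glutamate receptor 3 (Rattus norvegicus), read by thallium flux, with a stated time of 2.5 min (on this read-out higher numbers stand for an effect only at larger amounts of compound and lower numbers for an effect already at smaller amounts), are limits of the assay rather than numbers. Compound 1 gives only a limit, > 10000 nM. Compound 2 likewise gives only a limit, > 10000 nM, so compound 2 stands at the limit shared by every value shown here (the limit of > 10000 nM in this assay, at which 2 of the 2 values shown sit). Compound 3, `Cc1c(OCCCCOc2ccc(F)c(C(=O)O)c2)ccc(C(=O)CC2CCCC2)c1O`, is not yet measured in this assay. It differs from compound 2 by cyclopentylmethyl in place of isopropyl on a carbonyl carbon. Going by the values given here, no measured step between two compounds is available, so the size of this step cannot be read from the data. With both measured compounds at the limit, compound 3 is expected to remain at or near that limit, and the step that the limit leaves unreadable from compound 2 to compound 3 is estimated as none beyond the scatter. Compound 3 is therefore expected to give roughly 20000 nM, within 5000 nM to 100000 nM.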

Compound 3, half-maximal effective concentration: 2490 nM
The estimate for compound 3 lay 8.0-fold (0.90 log units) above the measured number; the whole stated range lies above it.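

In this assay, the series now shows an at least 4.0-fold lower number from compound 2 to compound 3 (0.60 log units; beyond the scatter), with cyclopentylmethyl in place of isopropyl on a carbonyl carbon. The aryl group matters as well: the series shows an at least 4.0-fold lower number from compound 1 to compound 3 (0.60 log units; beyond the scatter), with 3-carboxy-4-fluorophenyl in place of 4-carboxy-2-fluorophenyl on an oxygen on a saturated carbon. Both step sizes are minimum sizes, each starting from a limit rather than a number: the limit of > 10000 nM in this assay, at which 2 of the 3 values shown sit.

On these data alone, the true size of either step remains unknown. Also open, as far as these compounds go, is whether cyclohexylmethyl on that carbonyl carbon, or a nitrile in place of the carboxylic acid, would lower the number further.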